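The source may hold more compounds than are shown below. What is called first, only, known or untested is meant among the compounds shown, and "the series" means these compounds.

Measured so far in an ADME assay on cells (Macrophage, Mus musculus) for cytotoxicity, read by resazurin assay, with a stated time of 3 days; a higher number here means a weaker inhibitor, a lower number a stronger inhibitor:
compound 1 `O=C(Nc1cc(C(F)(F)F)cc(C(F)(F)F)c1)c1cccc(Cl)c1`, a limit of the assay: > 60000 nM
compound 2 `O=C(Nc1cc(C(F)(F)F)ccc1C(F)(F)F)c1cc(Cl)ccc1O`: 6600 nM
compound 3 `O=C(Nc1cc(C(F)(F)F)ccc1Cl)c1cc(Cl)ccc1O`: 3500 nM

Compound 1 gives no number in this assay, only the limit noted as the limit of > 60000 nM in this assay, at which 1 of the 3 values shown sits. Of the two numbers shown, compound 3 carries the lower value, yet the separation from compound 2 is a 1.9-fold lower number from compound 2 to compound 3 (0.28 log units; within the scatter), so the two compounds sit within the scatter of each other and no ranking between them is claimed.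

The next compound in the series is compound 4 `O=C(Nc1cc(C(F)(F)F)ccc1F)c1cc(Cl)ccc1O`, which differs from compound 3 by fluoro in place of chloro on an aromatic carbon. Within the data shown here, the only measured step that touches the same place on the shared core is that exchange of chloro for trifluoromethyl from compound 2 to compound 3, and that step stayed within the scatter. A swap of chloro for fluoro at the same aromatic carbon is a smaller change in the group than the one already measured, so no movement beyond the scatter is expected in this assay, with at most a modest rise in the number.

Compound 4 is therefore expected to give about 5000 nM in this assay, with a range from 2000 nM to 15000 nM. That estimate corresponds to an expected step of a 1.4-fold higher number from compound 3 to compound 4 (0.15 log units; within the scatter).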

Compound 4, half-maximal inhibitory concentration: 2600 nM
Compound 4: the middle estimate sits 1.9-fold (0.28 log units) above what was measured; the range from low to high includes it.
By their numbers in this assay, from the lowest: compounds 4, 3 and 2 (each within the scatter of the next, the first and the last beyond it). At a limit, above all of these: compound 1.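

On this aromatic carbon, para to a trifluoromethyl group, the exchange of chloro for fluoro in this assay gives a 1.3-fold lower number from compound 3 to compound 4 (0.13 log units; within the scatter), so these two halogens cannot be told apart at this position in this assay. Fluoro in place of trifluoromethyl gives the first step at this position that clears the scatter, a 2.5-fold lower number from compound 2 to compound 4 (0.40 log units; beyond the scatter), though it remains modest and compound 3 stands within the scatter of both neighbours, so the three groups separate only at the two ends of the set. No measurement shown here offers a reason for this modest separation, and the data tie it to no property of the groups.

Going by these compounds, whether an amine, a methoxy group or a nitrile on this same aromatic carbon would stay in this narrow band of numbers, or move well away from it, remains open, as does the reading with plain hydrogen there. Also open, on these data alone, is whether the modest step from trifluoromethyl to fluoro would hold if the chloro or the hydroxyl elsewhere on the shared core were exchanged for another group.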